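The source may report more compounds than this note shows. Statements on the series, on what has been measured and on what is new or still open speak of the compounds shown alone.

Measured compounds:

- Compound 1, `Cc1ccc(S(=O)(=O)N2CC[C@@H](Br)C[C@@H]2C2CCCCC2)cc1`: 14000 nM
- Compound 2, `Cc1ccc(S(=O)(=O)N2CC[C@@H](Br)C[C@@H]2c2ccccc2)cc1`: 36000 nM
- Compound 3, `Cc1ccc(S(=O)(=O)N2CCC(Br)=CC2C2CCCCC2)cc1`: 18000 nM

All three were tested in a functional assay on WiDr cells (Homo sapiens) for antiproliferative activity, read by sulforhodamine B assay, with a stated time of 48 h (a lower number here means a stronger inhibitor of growth, a higher number a weaker inhibitor of growth), and the numbers above are those results. Compound 1 and compound 2 share a core and differ in one place: phenyl in place of cyclohexyl on a saturated ring carbon. That single change gave a 2.6-fold higher number from compound 1 to compound 2 (0.41 log units; beyond the scatter), so compound 2 came out as the weaker growth inhibitor of the pair.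

Compound 3 has a different core from compound 1; the difference between the two cores is not broken down here. In this assay compound 3 gives 18000 nM, which sits within the usual scatter of compound 1 and of compound 2, so no order among these three can be drawn from compound 3 alone.

Compound 4, `Cc1ccc(S(=O)(=O)N2CCC(Br)=CC2c2ccccc2)cc1`, has not yet been measured. It stands to compound 3 as compound 2 stands to compound 1: phenyl in place of cyclohexyl on a saturated ring carbon. The place of the change is described in the same words for both pairs, so this is the same change made on the other core. Among the compounds with values here, with only one earlier example of this change, the expectation for compound 4 rests on it: the step is expected to be about a 2.5-fold higher number from compound 3 to compound 4 (0.40 log units; beyond the scatter), because compound 1 to compound 2 showed a 2.6-fold higher number from compound 1 to compound 2 (0.41 log units; beyond the scatter). On that basis compound 4 is expected to give about 45000 nM in this assay, with a plausible range from 20000 nM to 100000 nM.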

Compound 4, concentration for 50% growth inhibition: 29000 nM
Estimate against measurement, compound 4: 1.6-fold (0.19 log units) above; measured number inside the range.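

In this assay, phenyl in place of cyclohexyl on a saturated ring carbon gave a 1.6-fold higher number from compound 3 to compound 4 (0.21 log units; within the scatter), and the comparison with the earlier step reads: the same change on two cores in this assay, a 2.6-fold higher number (0.41 log units; beyond the scatter) from compound 1 to compound 2 and a 1.6-fold higher number (0.21 log units; within the scatter) from compound 3 to compound 4, 1.6-fold (0.20 log units) apart, within the scatter of two such steps. The gap between the two steps therefore gives no sign that this change behaves differently on the core of compound 3 and the core of compound 1, so the result from the first pair carries over as far as these data can test it. What this does not show is that compound 4 is a weaker growth inhibitor than compound 3: that step on its own lies within the scatter, only compound 1 and compound 2 are clearly separated, and two pairs make no rule for any further core.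

Only cyclohexyl and phenyl appear on that ring carbon among the compounds shown, so it remains open how a smaller group such as methyl, a longer alkyl chain, or a ring carrying an amine or a carboxylic acid would behave there. Bromo is also the only group shown on the ring atom that bears it, which leaves open whether chloro or a nitrile at that atom would give a different result on either core.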